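The compounds below may be only part of what the source reports. "The series", "measured", "known", "first", "only" and "open" are said of these compounds alone.

Measured compounds, each value a limit of the assay rather than a number:

Compound 1 `CN(C)c1ncnc2c1c(-c1ccoc1)cn2[C@@H]1O[C@H](CO)[C@@H](O)[C@H]1O`: > 20000 nM
Compound 2 `CN(C)c1ncnc2c1c(-c1cccs1)cn2[C@@H]1O[C@H](CO)[C@@H](O)[C@H]1O`: > 20000 nM
Compound 3 `Nc1nc(N)c2c(-c3cccs3)cn([C@@H]3O[C@H](CO)[C@@H](O)[C@H]3O)c2n1`: > 20000 nM

All three were tested in a functional assay on HCT-116 cells (Homo sapiens), read by MTT assay, with a stated time of 72 h (a lower number here means a stronger inhibitor, a higher number a weaker inhibitor), and none reached a readable value because of the limit of > 20000 nM in this assay, at which 3 of the 3 values shown sit. Compound 2 and compound 1 differ in one place, (furan-3-yl in place of thiophen-2-yl on an aromatic carbon), and the step that the two limits leave unreadable from compound 2 to compound 1, so nothing can be said about its size. How the core of compound 3 differs from the core of compound 2 is not broken down here.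

Compound 4 `Nc1nc(N)c2c(-c3ccoc3)cn([C@@H]3O[C@H](CO)[C@@H](O)[C@H]3O)c2n1` is still to be measured in this assay. It differs from compound 3 by furan-3-yl in place of thiophen-2-yl on an aromatic carbon, and the surroundings of the place are described in the same words as for the change from compound 2 to compound 1, so it is the same change. The expectation for compound 4 rests on compound 3 sitting at the limit with > 20000 nM and on the earlier change leaving compound 1 at the limit as well; the estimated step is a step that the limit leaves unreadable from compound 3 to compound 4. Compound 4 is therefore expected to give about 40000 nM, most likely again reported only as a limit, somewhere between 20000 nM and 200000 nM.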

Compound 4, half-maximal inhibitory concentration: > 20000 nM
Compound 4 ended at the assay's limit; the forecaster's own chance of this, stated with the estimate: 90%; the middle value lies beyond the limit too.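

No size can be read for the change from compound 3 to compound 4, because both values are limits of the assay rather than numbers: the limit of > 20000 nM in this assay, at which 4 of the 4 values shown sit.

The compounds shown leave open whether furan-3-yl and thiophen-2-yl differ at all in this assay, and which change to these structures, if any, would give a readable value.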